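Two Chlorines Instead of One on the Aryl Ring

This account rests on a few compounds, and the source may have more. Where it says the series, first, only, none or still open, it means among the compounds named here.

Compound 1 `O=C1c2ccccc2S(=O)(=O)N1CCCCCN1CCN(c2ccc(Cl)cc2)CC1` carries a 4-chlorophenyl group on the ring amine and, in an assay on HEK293 cells for displacement of a labelled ligand from 5-hydroxytryptamine receptor 7 (Homo sapiens) (a lower number here means a stronger inhibitor, a higher number a weaker inhibitor), gives 191 nM, the lowest of the three numbers measured. Compound 3 `O=C1c2ccccc2S(=O)(=O)N1CCCCN1CCN(c2cccc(Cl)c2Cl)CC1`, which bears a 2,3-dichlorophenyl group on a shorter chain, gives 372 nM in this assay, a value within the scatter of compound 1. Compound 2 `O=C1c2ccccc2S(=O)(=O)N1CCCCCCN1CCN(c2ncccn2)CC1`, with a pyrimidinyl group, gives 2520 nM, clearly weaker. Compound 4 `O=C1c2ccccc2S(=O)(=O)N1CCCCCN1CCN(c2cccc(Cl)c2Cl)CC1` differs from compound 1 by 2,3-dichlorophenyl in place of 4-chlorophenyl on an amine nitrogen in a ring. Since compound 3 with the same dichlorophenyl group gives 372 nM, no step beyond the scatter is expected from compound 1 to compound 4, a 1.4-fold higher number from compound 1 to compound 4 (0.15 log units; within the scatter). Compound 4 is therefore estimated at 270 nM, within a range of 120 nM to 650 nM.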

Compound 4, inhibition constant: 149 nM
Compound 4: the middle estimate sits 1.8-fold (0.26 log units) above what was measured; low and high end bracket the measured number.
By their numbers in this assay, from the lowest: compounds 4, 1 and 3 (each within the scatter of the next, the first and the last beyond it); then compound 2.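

With the chain and the rest of the core unchanged, 2,3-dichlorophenyl in place of 4-chlorophenyl on the ring amine nitrogen gives a 1.3-fold lower number from compound 1 to compound 4 (0.11 log units; within the scatter) in this assay. For the compounds shown here, the earlier compounds differed in more than one place, so this is the first view of the aryl change alone: here, the two chlorophenyl groups cannot be told apart. No measurement shown explains this result. Still open, going by these compounds, is how an unsubstituted phenyl or a methoxyphenyl group would compare at this position on the same chain.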